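The source may report more compounds than this note shows. Statements on the series, on what has been measured and on what is new or still open speak of the compounds shown alone.

Compound 1 `O=C(CCCCCCCc1ccccc1)CC(=O)N[C@H]1CCOC1=O` gives 10000 nM in a functional assay on NCI-H630 cells (Homo sapiens) for cytotoxicity, read by sulforhodamine B assay, with a stated time of 5 days; on this read-out higher numbers stand for weaker inhibition and lower numbers for stronger inhibition.
Compound 3 `O=C(CCCCCCCCc1ccccc1)CC(=O)N[C@H]1CCOC1=O` gives 10000 nM in this assay.
Compound 2 `O=C(CCCCCCCCc1ccccc1)N[C@H]1CCOC1=O` gives only a limit in this assay, > 100000 nM.

The first two compounds share a core and differ by one change, (benzyl in place of phenyl on a saturated chain carbon, seven bonds along the chain from a carbonyl carbon). The step that this change makes is no change at the digits printed from compound 1 to compound 3 (within the scatter). Compound 2 has a different core; how the core of compound 2 differs from the core of compound 1 is not broken down here. The value of compound 2 is a limit of this assay and not a number.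

Compound 4 `O=C(CCCCCCCCCc1ccccc1)N[C@H]1CCOC1=O` has not yet been measured. It differs from compound 2 by benzyl in place of phenyl on a saturated chain carbon, eight bonds along the chain from a carbonyl carbon. For the measured compounds named here, this is the same kind of change as the one from compound 1 to compound 3, but not the same: in the first pair the change sits seven bonds along the chain from a carbonyl carbon, in the second pair eight bonds along the chain from a carbonyl carbon. Beside the measured step of no change at the digits printed from compound 1 to compound 3 (within the scatter), the expected step in this assay is a number no higher from compound 2 to compound 4 (the limit leaves the size open). This expectation rests on the measured pair showing no change within the scatter and on compound 2 sitting at the limit of > 100000 nM in this assay, at which 1 of the 3 values shown sits, so that compound 4 is expected to sit near that limit as well. Compound 4 is estimated at 100000 nM, between 30000 nM and 300000 nM.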

Compound 4, half-maximal inhibitory concentration: > 100000 nM
Compound 4: only a limit was reported; the forecaster's own chance of this, stated with the estimate: 70%; the middle value lies on the limit itself.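

In this assay compound 4 gives > 100000 nM, which is a limit and not a number. For the compounds shown here, compound 2 also gives a limit, > 100000 nM, so no step between compound 2 and compound 4 can be read. Both compounds rest on the same mark: the limit of > 100000 nM in this assay, at which 2 of the 4 values shown sit. The compounds shown leave open how compound 2 and compound 4 compare, and whether benzyl in place of phenyl alters this assay on their core.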